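The source may report more compounds than this note shows. Statements on the series, on what has been measured and on what is new or still open speak of the compounds shown alone.

Working notes on a small selenium series sharing one core. Compound 1 `CCCCC[Se]c1nc(NCc2ccc(SC)cc2)c2ccccc2n1`, compound 2 `CSc1ccc(CNc2nc([SeH])nc3ccccc23)cc1` and compound 3 `Nc1nc([SeH])nc2ccccc12` have been measured; compound 4 `CCCCC[Se]c1nc(N)c2ccccc2n1` has not. In a functional assay on HT-29 cells (Homo sapiens) for cytotoxicity, read by MTT assay, with a stated time of 72 h (a lower number here means a stronger inhibitor of growth, a higher number a weaker inhibitor of growth), compound 1 gives > 100000 nM, which is a limit of the assay. In this assay compound 2 gives > 100000 nM, also a limit. In this assay compound 3 gives > 100000 nM, again a limit. The change pentyl in place of hydrogen on a selenium produced a step that the two limits leave unreadable from compound 2 to compound 1, unreadable because the limit of > 100000 nM in this assay, at which 3 of the 3 values shown sit, covers both ends. The difference between the core of compound 2 and the core of compound 3 is not broken down here. Compound 4 arises from compound 3 by the same change, (pentyl in place of hydrogen on a selenium). For compound 4 the expected step is a step that the limit leaves unreadable from compound 3 to compound 4. That expectation rests on compound 3 sitting at the limit of > 100000 nM in this assay, at which 3 of the 3 values shown sit, with every value shown at the same limit. For compound 4 the estimate is 150000 nM, between 50000 nM and 500000 nM.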

Compound 4, concentration for total growth inhibition: > 100000 nM
Compound 4: no number, only a limit (the forecaster's own chance of this, stated with the estimate: 85%); the middle value lies beyond the limit too.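

No step can be read from compound 3 to compound 4, because both ends sit at the same limit: the limit of > 100000 nM in this assay, at which 4 of the 4 values shown sit.

The compounds shown leave open whether pentyl in place of hydrogen on a selenium changes growth inhibition at all.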